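This account rests on a few compounds, and the source may have more. Where it says the series, first, only, none or still open, it means among the compounds named here.

Measured so far:
Compound 1, `COC(=O)[C@@]1(C)CCC=C2[C@@H]1CC[C@@H](C)[C@]2(C)Cc1c[nH]c2ccc(F)cc12` — 8000 nM
Compound 2, `COC(=O)[C@@]1(C)CCC=C2[C@@H]1CC[C@@H](C)[C@]2(C)Cc1c[nH]c2ccc(C(F)(F)F)cc12` — 18000 nM

In a functional assay on WiDr cells (Homo sapiens) for inhibition, read by sulforhodamine B assay, with a stated time of 48 h (a higher number here means a weaker inhibitor of growth, a lower number a stronger inhibitor of growth), compound 1 gives 8000 nM and compound 2 gives 18000 nM. For the measured compounds named here, of the two numbers known, compound 2 stands with the highest one, the weaker growth inhibitor; the only step measured, a 2.3-fold higher number from compound 1 to compound 2 (0.35 log units; beyond the scatter), separates it from compound 1.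

Compound 3, `COC(=O)[C@@]1(C)CCC=C2[C@@H]1CC[C@@H](C)[C@]2(C)Cc1c(C)[nH]c2ccc(C(F)(F)F)cc12`, differs from compound 2 by methyl in place of hydrogen on an aromatic carbon: the methyl sits on an aromatic carbon of the five-membered aromatic ring with one nitrogen, next to the ring nitrogen and next to the ring atom that bears a large group. Going by the values given here, no measured step bears on this change: the one step seen concerns a different group at a different place on the fused ring system, so it gives no guidance on a methyl entering here. With nothing to point either way, the expectation for this assay is a number close to that of compound 2, with no step beyond the scatter and a wide range in both directions. Compound 3 is therefore estimated at 18000 nM, within 6000 nM to 50000 nM, which would mean no change at the digits printed from compound 2 to compound 3 (within the scatter).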

Compound 3, concentration for 50% growth inhibition: 21000 nM
Beside the measured number, compound 3's estimate is 1.2-fold (0.07 log units) below it, within the range that was stated.
By their numbers in this assay, from the lowest: compound 1; then compounds 2 and 3 (each within the scatter of the next).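

In this assay, methyl in place of hydrogen on the aromatic carbon next to the ring nitrogen gives a 1.2-fold higher number from compound 2 to compound 3 (0.07 log units; within the scatter), so this assay does not separate the two compounds. For the compounds shown here, this is the first reading at this position, since the only earlier step, a 2.3-fold higher number from compound 1 to compound 2 (0.35 log units; beyond the scatter), concerned a different group at a different place, and it shows that, with trifluoromethyl present, this hydrogen can give way to methyl while the number stays within the scatter. No measurement here explains this result.

Still open, going by these compounds, is whether a longer chain such as ethyl, an amine or a carboxylic acid on this same carbon would move the number beyond the scatter, in either direction. Also open, on these data alone, is whether methyl at this position would read the same with fluoro in place of trifluoromethyl, as in compound 1, so this one step describes only the trifluoromethyl pair.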